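This account rests on a few compounds, and the source may have more. Where it says the series, first, only, none or still open, it means among the compounds named here.

In a functional assay on MCF7 cells (Homo sapiens) for inhibition, read by MTT assay, with a stated time of 72 h (on this read-out lower numbers stand for stronger inhibition of growth and higher numbers for weaker inhibition of growth), three compounds built on one shared core have been measured. Compound 1 `O=S(=O)(NCCCNCc1ccccc1Cl)c1cc(C(F)(F)F)cc(C(F)(F)F)c1` gives 8800 nM, compound 2 `O=S(=O)(NCCCNCc1ccc(C(F)(F)F)cc1)c1cc(C(F)(F)F)cc(C(F)(F)F)c1` gives 1400 nM, and compound 3 `CN(CCCNS(=O)(=O)c1cc(C(F)(F)F)cc(C(F)(F)F)c1)Cc1ccccc1` gives 16000 nM. The gap a 1.8-fold higher number from compound 1 to compound 3 (0.26 log units; within the scatter) lies within the scatter, so compound 3 and compound 1 cannot be ranked, whereas the value of compound 2 stands clearly lower than that of compound 3. Compound 4 `COc1ccccc1CNCCCNS(=O)(=O)c1cc(C(F)(F)F)cc(C(F)(F)F)c1` differs from compound 3 by (2-methoxybenzyl)amino in place of benzyl(methyl)amino on a saturated chain carbon, three bonds along the chain from a sulfonamide nitrogen. This change nearly reverses a 1.8-fold higher number from compound 1 to compound 3 (0.26 log units; within the scatter), which stayed within the scatter, while a 6.3-fold lower number from compound 1 to compound 2 (0.80 log units; beyond the scatter) shows that a change on this ring can move the number modestly. Compound 4 is therefore expected to show a 2.3-fold lower number from compound 3 to compound 4 (0.36 log units; beyond the scatter), a small drop. For compound 4 the estimate is 7000 nM, ranging from 2000 nM to 20000 nM.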

Compound 4, concentration for 50% growth inhibition: 2600 nM
Compound 4: the middle estimate sits 2.7-fold (0.43 log units) above what was measured; the range from low to high includes it.
By their numbers in this assay, from the lowest: compounds 2 and 4 (each within the scatter of the next); then compounds 1 and 3 (each within the scatter of the next).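

Exchanging benzyl(methyl)amino for (2-methoxybenzyl)amino gives a 6.2-fold lower number from compound 3 to compound 4 (0.79 log units; beyond the scatter), so this change on the saturated chain carbon moves the number beyond the scatter. Methoxy in place of chloro on an aromatic carbon gives a 3.4-fold lower number from compound 1 to compound 4 (0.53 log units; beyond the scatter), showing that this swap alone matters, while a 1.9-fold higher number from compound 2 to compound 4 (0.27 log units; within the scatter) leaves those two unranked. No measured evidence accounts for these steps.

From the compounds shown here alone, the step to compound 4 changes both the amine methyl and the ring methoxy, so their separate shares remain open. Going by these compounds, how a nitrile on the ring or a longer chain would read also remains open.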